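A chloro group returns in compound 3

The source may hold more compounds than are shown below. What is called first, only, known or untested is meant among the compounds shown, and "the series" means these compounds.

In a functional assay on the whole organism for inhibition, with Rattus norvegicus as the target (a lower number here means that less compound is needed, a higher number that more compound is needed for the effect), compound 1 `CC(C)c1ccc(OC(C)(Cc2ccc(Cl)cc2)C(=O)NS(=O)(=O)C(F)(F)F)cc1` gives 5 mg/kg. Compound 2 `CCCc1ccc(CC(C)(Oc2ccc(C(C)C)cc2)C(=O)NS(=O)(=O)C(F)(F)F)cc1` has only a limit, > 10 mg/kg, and no number. Compound 3 `CC(C)c1ccc(OC(C)(C(=O)NS(=O)(=O)C(F)(F)F)C(C)c2ccc(Cl)cc2)cc1` differs from compound 2 as follows: 1-(4-chlorophenyl)ethyl in place of 4-propylbenzyl on a saturated chain carbon bound to a carbonyl carbon, an oxygen on an aromatic ring and a saturated chain carbon. This puts 1-(4-chlorophenyl)ethyl in place of 4-propylbenzyl, so the chloro group of compound 1 returns. Within the data shown here, one measured step bears on this: an at least 2.0-fold higher number from compound 1 to compound 2 (0.30 log units; that floor lies within the scatter). A change of similar size in the opposite direction is therefore expected in this assay, though this rests on that single step. The estimated step is an at least 1.4-fold lower number from compound 2 to compound 3 (0.15 log units; that floor lies within the scatter). Compound 3 is expected at 7 mg/kg, within a range of 2.5 mg/kg to 20 mg/kg.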

Compound 3, dose for half-maximal effect: > 10 mg/kg
Compound 3: only a limit was reported; the forecaster's own chance of this, stated with the estimate: 30%; middle value at least 1.4-fold (0.15 log units) away from the limit.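

Methyl in place of hydrogen on a saturated chain carbon bound to an aromatic carbon and a saturated chain carbon gives an at least 2.0-fold higher number from compound 1 to compound 3 (0.30 log units; that floor lies within the scatter) in this assay. With the chloro group present, this single methyl is therefore enough to leave only a limit in place of a number. The step from compound 2 to compound 3 cannot be read because both compounds stop at the same limit: the limit of > 10 mg/kg in this assay, at which 2 of the 3 values shown sit.

As far as these compounds go, the true values of compound 2 and compound 3 remain open. So does whether an ethyl or a hydroxyl group at this carbon would give a measurable number.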